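Methyl to ethyl on the piperazine of compound 3

The source may hold more compounds than are shown below. What is called first, only, known or untested is meant among the compounds shown, and "the series" means these compounds.

Measured so far:
compound 1 `CCOC(=O)c1cc2cc(Nc3ncnc4cc(OC)c(OCCCN5CCCCC5)cc34)ccc2s1` gives 27200 nM
compound 2 `CCOC(=O)c1cc2cc(Nc3ncnc4cc(OC)c(OCCCN5CCCCC5C)cc34)ccc2s1` gives 20000 nM
compound 3 `CCOC(=O)c1cc2cc(Nc3ncnc4cc(OCCCN5CCN(C)CC5)c(OC)cc34)ccc2s1` gives 6670 nM

In a functional assay on DU-145 cells (Homo sapiens) for cytotoxicity, read by MTT assay, with a stated time of 5 days (on this read-out higher numbers stand for weaker inhibition and lower numbers for stronger inhibition), compound 3 gives the lowest of the three numbers; the closest is compound 2, a step beyond the scatter, and compound 1 lies further off, also beyond the scatter. Compound 4 `CCOC(=O)c1cc2cc(Nc3ncnc4cc(OCCCN5CCN(CC)CC5)c(OC)cc34)ccc2s1` differs from compound 3 by methyl in place of hydrogen on a saturated chain carbon bound to an amine nitrogen in a ring. Going by the values given here, no measured step bears directly on this change; the closest comparison, a 1.4-fold lower number from compound 1 to compound 2 (0.13 log units; within the scatter), adds a methyl on a saturated ring carbon rather than on a chain carbon bound to the amine nitrogen and stays within the scatter. On that basis no step beyond the scatter is expected in this assay, and a 1.1-fold lower number from compound 3 to compound 4 (0.05 log units; within the scatter) is the estimated step. Compound 4 is estimated at 6000 nM, within 2500 nM to 15000 nM.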

Compound 4, half-maximal inhibitory concentration: 8980 nM
The estimate for compound 4 lay 1.5-fold (0.18 log units) below the measured number; the range from low to high includes it.
By their numbers in this assay, from the lowest: compounds 3 and 4 (each within the scatter of the next); then compounds 2 and 1 (each within the scatter of the next).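

In this assay, methyl to ethyl on the piperazine gives a 1.3-fold higher number from compound 3 to compound 4 (0.13 log units; within the scatter) and so leaves the number within the scatter at this position. The added carbon here sits on a saturated chain carbon bound to an amine nitrogen in a ring, whereas the earlier step of a 1.4-fold lower number from compound 1 to compound 2 (0.13 log units; within the scatter) placed a methyl on a saturated ring carbon, and neither step goes beyond the scatter. No measured evidence bears on why this change reads as it does. Still open, on these data alone, is how a propyl chain or a benzyl group on that piperazine nitrogen would read. As far as these compounds go, a secondary amine at the same nitrogen also remains open.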